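From 4-Methylphenyl to 4-Chloro-3-fluorophenyl at the Limit

A few compounds are considered here, and "the series" means these few. Any claim that something is new, unique, unknown or untested is made for them only; others in the source may bear on it.

Measured in a functional assay on ECV-304 cells (Homo sapiens) for cytotoxicity (on this read-out lower numbers stand for stronger inhibition and higher numbers for weaker inhibition), so far:
Compound 1 `Cc1ccc(/C=C2\SC(=S)N(NS(=O)(=O)c3ccccc3)C2=O)cc1` gives > 50000 nM as a limit
Compound 2 `O=C1/C(=C/c2ccc(Cl)c(Cl)c2)SC(=S)N1NS(=O)(=O)c1cccs1` gives > 50000 nM as a limit

Compound 1 stands at > 50000 nM in this assay and this is a limit rather than a number. Compound 2 gives > 50000 nM and that is a limit as well. The whole record so far is the limit of > 50000 nM in this assay, at which 2 of the 2 values shown sit, and no numerical value has been obtained. Compound 3 `O=C1/C(=C/c2ccc(Cl)c(F)c2)SC(=S)N1NS(=O)(=O)c1ccccc1` has not yet been measured. Against compound 1 the change is 4-chloro-3-fluorophenyl in place of 4-methylphenyl on a double-bonded chain carbon bound to a double-bonded ring carbon and amounts to 4-chloro-3-fluorophenyl in place of 4-methylphenyl on a double-bonded chain carbon bound to a double-bonded ring carbon. Going by the values given here, no step between measured compounds is available to size such a change. The expectation therefore rests on compound 1 and compound 2 sharing the limit of > 50000 nM in this assay, at which 2 of the 2 values shown sit, and it points to no shift beyond the scatter in either direction. The expected step runs a number no higher from compound 1 to compound 3 (the limit leaves the size open) and is estimated to stay small in this assay as a result. For compound 3 the expected value is 50000 nM with an estimated range of 15000 nM to 100000 nM in this read-out, and another limit would be no surprise.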

Compound 3, half-maximal inhibitory concentration: > 50000 nM
Compound 3 gave a limit, no number (the forecaster's own chance of this, stated with the estimate: 70%); the middle value lies on the limit itself.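

In this assay compound 3 gives > 50000 nM, which is a limit and not a number. Compound 1 also stands at a limit, so no step can be read between compound 1 and compound 3. The compounds shown leave open whether 4-chloro-3-fluorophenyl in place of 4-methylphenyl changes the read-out at all, for the record holds only: the limit of > 50000 nM in this assay, at which 3 of the 3 values shown sit.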